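The source may report more compounds than this note shows. Statements on the series, on what has been measured and on what is new or still open speak of the compounds shown alone.

Measured so far in an assay on isolated protein for inhibition of Indoleamine 2,3-dioxygenase 1 (Homo sapiens), read by HPLC, with a stated time of 60 min, in the presence of a further agent that is not named here; on this read-out higher numbers stand for weaker inhibition and lower numbers for stronger inhibition:

Compound 1 `COc1ccccc1Sc1c[nH]c2ccc(Cl)cc12` gives 17500 nM.
Compound 2 `COc1ccc(Sc2c[nH]c3ccc(Cl)cc23)cc1` gives 16000 nM.
Compound 3 `Cc1ccccc1Sc1c[nH]c2ccc(Cl)cc12` gives 21000 nM.

Compounds 1 and 2 are built from the same atoms joined differently; the difference between the two cores is not broken down here. All three numbers lie within the scatter of one another, so no order among them can be read. From compound 1 to compound 3 the change is methyl in place of methoxy on an aromatic carbon and the step is a 1.2-fold higher number from compound 1 to compound 3 (0.08 log units; within the scatter).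

Compound 4 `Cc1ccc(Sc2c[nH]c3ccc(Cl)cc23)cc1` is still to be measured in this assay. From compound 2 it differs by methyl in place of methoxy on an aromatic carbon. This is the same kind of change as that seen from compound 1 to compound 3, not the same one: there the place is ortho to a large group, here it is para to a large group.

The step from compound 2 to compound 4 is expected to be about a 1.2-fold higher number from compound 2 to compound 4 (0.07 log units; within the scatter) because a 1.2-fold higher number from compound 1 to compound 3 (0.08 log units; within the scatter) stayed within the scatter. Compound 4 is accordingly estimated at 19000 nM in this assay, with a range from 9000 nM to 40000 nM.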

Compound 4, half-maximal inhibitory concentration: > 200000 nM
Compound 4 ended at the assay's limit; the forecaster's own chance of this, stated with the estimate: 5%; at least 10-fold (1.02 log units) between middle value and limit.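

In this assay compound 4 gives > 200000 nM, which is a limit of the assay and not a number. Methyl in place of methoxy, para to a large group, gives an at least 12-fold higher number from compound 2 to compound 4 (1.09 log units; beyond the scatter), so the near-silent result of this change on the core of compound 1 does not carry over to the core of compound 2: the same change on two cores in this assay, a 1.2-fold higher number (0.08 log units; within the scatter) from compound 1 to compound 3 and an at least 12-fold higher number (1.09 log units; beyond the scatter) from compound 2 to compound 4, at least 10-fold (1.01 log units) apart, beyond the scatter of two such steps With one pair on each core, this does not show why the two steps part, nor how large the step to compound 4 really is, since it is bounded on one side only: the limit of > 200000 nM in this assay, at which 1 of the 4 values shown sits.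

Still open, from the compounds shown here alone, is whether the loss belongs to methyl itself or would follow any replacement of methoxy at this place. An amine, a hydroxyl or a longer chain such as ethoxy, para to a large group, would show whether a measurable number can be held on this core.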